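Fixing Both Stereocentres on the Methylated Hydroxypiperidine Amide

The compounds below may be only part of what the source reports. "The series", "measured", "known", "first", "only" and "open" are said of these compounds alone.

Compound 1, `COc1cc(C(=O)N2CCC(O)CC2)cc2nc(NCc3cccc(Cl)c3)oc12`, gives 352 nM in an assay on isolated protein for inhibition of thyroid hormone receptor beta (Homo sapiens), read by fluorescence, with a stated time of 30 min; a higher number here means a weaker inhibitor, a lower number a stronger inhibitor.
Compound 2, `COc1cc(C(=O)N2CC[C@@H](O)C(C)(C)C2)cc2nc(NCc3cccc(Cl)c3)oc12`, gives 35 nM in this assay.
Compound 3, `COc1cc(C(=O)N2CCC(O)C(C)C2)cc2nc(NCc3cccc(Cl)c3)oc12`, gives 25 nM in this assay.

Compound 3 has the lowest number of the three in this assay. Its closest neighbour sits within the scatter (a 1.4-fold lower number from compound 2 to compound 3 (0.15 log units; within the scatter)), while the gap to the weakest compound is clear (a 14-fold lower number from compound 1 to compound 3 (1.15 log units; beyond the scatter)).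

Compound 4, `COc1cc(C(=O)N2CC[C@H](O)[C@@H](C)C2)cc2nc(NCc3cccc(Cl)c3)oc12`, keeps every atom and bond of compound 3 and differs only in how the ring is drawn: the two compounds have the same atoms and bonds; at least one stereo element is drawn with a configuration in one of them and without one in the other: 2 of 2 stereo elements differ; a stereocentre at a saturated ring carbon is drawn without a configuration in compound 3 and S in compound 4; a stereocentre at a saturated ring carbon is drawn without a configuration in compound 3 and S in compound 4. Compound 3 is therefore best read as an unresolved mixture of stereoisomers, and compound 4 as one defined member of it. Within the data shown here, none of the measured steps bears directly on this kind of change: a 10-fold lower number from compound 1 to compound 2 (1.00 log units; beyond the scatter) and a 14-fold lower number from compound 1 to compound 3 (1.15 log units; beyond the scatter) both concern methyl groups entering the ring, not configuration. Among the measured compounds shown here, compound 2, the only measured compound with a drawn configuration, offers no comparison to an undrawn partner. A single isomer could carry more or less of the mixture's activity, so the direction is open; a step within the scatter is the most reasonable expectation, with a slight lean toward a lower number: a 1.4-fold lower number from compound 3 to compound 4 (0.14 log units; within the scatter). Compound 4 is accordingly estimated at 18 nM, within a range from 7 nM to 60 nM.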

Compound 4, half-maximal inhibitory concentration: 120 nM
Compound 4: middle estimate off by 6.7-fold (0.82 log units), on the low side, outside the stated range (above it).
By their numbers in this assay, from the lowest: compounds 3 and 2 (each within the scatter of the next); then compound 4; then compound 1.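

In this assay, among these compounds, the configuration of the 4-hydroxy-3-methylpiperidin-1-yl amide clearly matters, which none of the earlier compounds could show: drawing both stereocentres gives a 4.8-fold higher number from compound 3 to compound 4 (0.68 log units; beyond the scatter), so if the undrawn material is a mixture, this isomer cannot be the member carrying most of its activity, and at least one other member should give a lower number. Among the compounds shown here, the single methyl group still counts for something in this isomer, with a 2.9-fold lower number from compound 1 to compound 4 (0.47 log units; beyond the scatter), yet the defined compound does not match the dimethyl amide, as a 3.4-fold higher number from compound 2 to compound 4 (0.54 log units; beyond the scatter) shows. Reading the earlier number as that of a mixture, and not of one substance, rests on a single structural fact: the fact that one of compounds 3 and 4 is drawn with a defined configuration and the other without, at the place where they differ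

The compounds shown leave open which of the other stereoisomers accounts for the lower number of the undrawn material, and how low a single isomer can go. They also leave open whether an ethyl group in place of the methyl, or an amine in place of the hydroxyl, would keep the gain over the unmethylated amide.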